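The source may report more compounds than this note shows. Statements on the series, on what has been measured and on what is new or still open speak of the compounds shown alone.

Values in a functional assay on SK-OV-3 cells (Homo sapiens) for cytotoxicity (a higher number here means a weaker inhibitor of growth, a lower number a stronger inhibitor of growth), for the three measured compounds

- compound 1 `COc1ccc(C2=C(c3ccc(SC)cc3)CC3CCCN3C2=O)cc1Br` gives 3000 nM
- compound 2 `CSc1ccc(C2=C(c3ccc(C)c(C)c3)C(=O)N3CCCC3C2)cc1` gives 300 nM
- compound 3 `CSc1ccc(C2=C(c3ccc(F)c(C)c3)C(=O)N3CCCC3C2)cc1` gives 300 nM

Compound 3 stands level with compound 2, and the two share the lowest number of the three, well apart from compound 1. The next compound, compound 4 `CSc1ccc(C2=C(c3ccc(O)cc3)C(=O)N3CCCC3C2)cc1`, swaps the whole aryl group on a double-bonded ring carbon (4-hydroxyphenyl in place of 4-fluoro-3-methylphenyl on a double-bonded ring carbon).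

Among the measured compounds shown here, three measured steps bear on this swap, and all concern the same aryl group. Replacing 3-bromo-4-methoxyphenyl gave a modest fall in the number both times (a 10-fold lower number from compound 1 to compound 2 (1.00 log units; beyond the scatter)) and (a 10-fold lower number from compound 1 to compound 3 (1.00 log units; beyond the scatter)). Fluoro in place of methyl on an aromatic carbon gave no step beyond the scatter (no change at the digits printed from compound 2 to compound 3 (within the scatter)). So this group can move the number, yet no measured compound carries 4-hydroxyphenyl. For the measured compounds named here, the only measured group containing oxygen belongs to compound 1, at 3000 nM, and that group also carries bromo, so it is a loose guide at best. Some rise in the number is therefore expected, smaller than the full gap to compound 1, and it is estimated as follows (a 3.3-fold higher number from compound 3 to compound 4 (0.52 log units; beyond the scatter)). For compound 4 the expected value is 1000 nM, with an estimated range from 250 nM to 5000 nM.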

Compound 4, concentration for 50% growth inhibition: > 100000 nM
Compound 4: a limit, no number (the forecaster's own chance of this, stated with the estimate: 10%); middle value at least 100-fold (2.00 log units) from the limit.
By their numbers in this assay, from the lowest: compounds 2 and 3 (each within the scatter of the next); then compound 1. At a limit, above all of these: compound 4.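

In this assay compound 4 stands at a limit of the assay, which is not a number: the limit of > 100000 nM in this assay, at which 1 of the 4 values shown sits. The earlier swaps of this aryl group, on a double-bonded ring carbon, left measurable growth inhibition in place, whereas 4-hydroxyphenyl gives an at least 330-fold higher number from compound 3 to compound 4 (2.52 log units; beyond the scatter), along with an at least 330-fold higher number from compound 2 to compound 4 (2.52 log units; beyond the scatter) and an at least 33-fold higher number from compound 1 to compound 4 (1.52 log units; beyond the scatter). Among the compounds shown here, this position is therefore far more sensitive to the choice of group than the earlier compounds could show, and even the poorest earlier group, 3-bromo-4-methoxyphenyl, lies well short of this limit, so carrying oxygen on the ring does not by itself bring such a loss.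

For the compounds shown here, the swap changes more than one feature at once, since the entering group counts a hydrogen-bond donor where the leaving group has none, and it also has only one substituent on its ring where the three other aryl groups have two. From the compounds shown here alone, a 4-methoxyphenyl group, a 4-methylphenyl group or a 4-hydroxy-3-methylphenyl group at this position would help to separate these features, and the true size of the step stays open while compound 4 has only a limit.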